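The source may report more compounds than this note shows. Statements on the series, on what has been measured and on what is new or still open speak of the compounds shown alone.

Among the compounds with values here, in a functional assay on PC-3 cells (Homo sapiens) for antiproliferative activity, read by MTT assay, with a stated time of 48 h (a higher number here means a weaker inhibitor, a lower number a stronger inhibitor), compound 2, whose structure is `O=C(Nc1ccc(Cl)c(Cl)c1)Nc1nnc(Sc2ncnc3scc(-c4ccncc4)c23)s1`, gives 3600 nM, and among the two numbers measured so far this is the lowest. Its nearest neighbour is compound 1, with structure `O=C(Nc1cccc(Cl)c1)Nc1nnc(Sc2ncnc3scc(-c4ccncc4)c23)s1`, which in this assay gives 8000 nM. The step between them, a 2.2-fold lower number from compound 1 to compound 2 (0.35 log units; beyond the scatter), came from a chloro in place of hydrogen on an aromatic carbon, and its size, while modest, lies beyond the scatter.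

Compound 3, with structure `O=C(Nc1ccc(Cl)cc1)Nc1nnc(Sc2ncnc3scc(-c4ccncc4)c23)s1`, has not yet been tested. Compared with compound 2 the change is hydrogen in place of chloro on an aromatic carbon; put another way, the 3,4-dichlorophenyl becomes a 4-chlorophenyl. Within the data shown here, only one measured step bears on this: the step from compound 1 to compound 2, in which adding a chloro lowered the number modestly. Removing a chloro, though at a different position on the same ring, is expected to move the number back up by a comparable, modest amount, so the step of a 1.8-fold higher number from compound 2 to compound 3 (0.26 log units; within the scatter) is the estimate. Compound 3 is therefore estimated at 6500 nM in this assay, with a likely range from 3000 nM to 14000 nM.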

Compound 3, half-maximal inhibitory concentration: 7700 nM
Compound 3: middle estimate off by 1.2-fold (0.07 log units), on the low side; the measured number falls inside the stated range.
By their numbers in this assay, from the lowest: compound 2; then compounds 3 and 1 (each within the scatter of the next).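

Read together with the earlier step, the new result shows that in this assay either single chloro can be lost from the 3,4-dichlorophenyl with a similar outcome, since taking away the chloro on the ring carbon ortho to the other chloro gives a 2.1-fold higher number from compound 2 to compound 3 (0.33 log units; beyond the scatter) and this step is of modest size, like the step in the other direction at the other ring position, which reads a 2.2-fold lower number from compound 1 to compound 2 (0.35 log units; beyond the scatter) in the earlier pair. The placing of a lone chloro makes no readable difference here, since 4-chlorophenyl in place of 3-chlorophenyl on the amide-type nitrogen gives a 1.0-fold lower number from compound 1 to compound 3 (0.02 log units; within the scatter) and so compound 1 and compound 3 cannot be told apart. Among these three compounds, then, what separates compound 2 from the other two is that its ring carries both chloro groups, not which single position is filled, and no measurement shown explains this pattern.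

As far as these compounds go, whether a plain phenyl with no chloro at all would continue this trend stays open. So does whether a methoxy group, a fluoro group or an amine on the same ring would behave as a chloro does in this series.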